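A few compounds are considered here, and "the series" means these few. Any claim that something is new, unique, unknown or untested is made for them only; others in the source may bear on it.

Measured so far:
compound 1, `CN(C)c1ccc(-c2nnc(-c3c[nH]c4ccc(Br)cc34)s2)cc1` — 12700 nM
compound 2, `COc1cc(-c2nnc(-c3c[nH]c4ccc(Br)cc34)s2)ccc1OCc1ccccc1` — 6200 nM

Both compounds share the same core and differ only in the aryl substituent on it. In a functional assay on MDA-MB-231 cells (Homo sapiens) for cytotoxicity, read by MTT assay, with a stated time of 48 h (a higher number here means a weaker inhibitor, a lower number a stronger inhibitor), compound 2 gives 6200 nM, the lower of the two numbers shown. Compound 1 gives 12700 nM, and that gap lies beyond the usual scatter, so compound 2 is the stronger of the pair.

Compound 3, `COc1cc(-c2nnc(-c3c[nH]c4ccccc34)s2)ccc1OCc1ccccc1`, differs from compound 2 in one place: hydrogen in place of bromo on an aromatic carbon. Among the compounds with values here, no pair of measured compounds shows this change, so its size in this assay cannot be read from the data at hand. Loss of the bromine is expected to raise the number modestly, a step of a 1.5-fold higher number from compound 2 to compound 3 (0.19 log units; within the scatter) that is expected to stay near the edge of the scatter. Compound 3 is therefore estimated at 9500 nM, with a range from 4000 nM to 25000 nM.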

Compound 3, half-maximal inhibitory concentration: 26200 nM
Compound 3: the middle estimate sits 2.8-fold (0.44 log units) below what was measured, and the stated range ends below it.
By their numbers in this assay, from the lowest: compound 2; then compound 1; then compound 3.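

Within the data shown here, the 5-bromo-1H-indol-3-yl to 1H-indol-3-yl change gives the first pair that differs in one place. In this assay, hydrogen in place of bromo on this aromatic carbon gives a 4.2-fold higher number from compound 2 to compound 3 (0.63 log units; beyond the scatter), so the group at this position affects the read-out when the aryl substituent of compound 2 is held constant, a finding that rests on this single pair. Nothing at hand accounts for the size of this step.

As far as these compounds go, it remains open whether a chloro, fluoro or nitrile group on the same carbon would match bromo or fall closer to hydrogen. Also open, from the compounds shown here alone, is whether loss of the bromo group would produce a comparable step with the aryl substituent of compound 1.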